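The compounds below may be only part of what the source reports. "The series", "measured", "known", "first", "only" and "open" are said of these compounds alone.

Compound 1 `N#Cc1ccc(/C=C/S(=O)(=O)Cc2ccc(Nc3ncnc4ccccc34)cc2)cc1` is the starting point. In a functional assay on OVCAR-8 cells (Homo sapiens) (on this read-out lower numbers stand for stronger inhibition of growth and higher numbers for weaker inhibition of growth), compound 1 gives only a limit, > 100000 nM, as recorded in the limit of > 100000 nM in this assay, at which 1 of the 3 values shown sits. Compound 4 `O=S(=O)(/C=C/c1ccc(O)cc1)Cc1ccc(Nc2ncnc3ccccc23)cc1` carries the change (hydroxy in place of cyano on an aromatic carbon). Two measured steps change the same place: compound 2 `O=S(=O)(/C=C/c1ccc(Br)cc1)Cc1ccc(Nc2ncnc3ccccc23)cc1` gives 38000 nM in this assay, a step of an at least 2.6-fold lower number from compound 1 to compound 2 (0.42 log units; beyond the scatter); compound 3 `O=S(=O)(/C=C/c1ccc(Cl)cc1Cl)Cc1ccc(Nc2ncnc3ccccc23)cc1` gives 4000 nM, a step of an at least 25-fold lower number from compound 1 to compound 3 (1.39 log units; beyond the scatter), and from compound 2 to compound 3 the step is a 9.5-fold lower number from compound 2 to compound 3 (0.98 log units; beyond the scatter). Hydroxy is not a halogen, so these steps bear on the new change only loosely; a lower number than for compound 1 is expected, but perhaps not beyond the scatter. The estimate for compound 4 is 50000 nM, between 10000 nM and 200000 nM, a step of an at least 2.0-fold lower number from compound 1 to compound 4 (0.30 log units; that floor lies within the scatter).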

Compound 4, concentration for 50% growth inhibition: 1000 nM
Estimate against measurement, compound 4: 50-fold (1.70 log units) above, and the stated range ends above it.
By their numbers in this assay, from the lowest: compound 4; then compound 3; then compound 2. At a limit, above all of these: compound 1.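

In this assay a halogen is not needed at this place for a low number: hydroxy gives a 38-fold lower number from compound 2 to compound 4 (1.58 log units; beyond the scatter) and also a 4.0-fold lower number from compound 3 to compound 4 (0.60 log units; beyond the scatter) with no second substituent on the ring. Compound 4 therefore has the lowest number of the compounds shown. Against cyano the change gives an at least 100-fold lower number from compound 1 to compound 4 (2.00 log units; beyond the scatter) but that is only a floor, since the starting value is a limit: the limit of > 100000 nM in this assay, at which 1 of the 4 values shown sits.

As far as these compounds go, whether methoxy or an amine at this place would match hydroxy stays open. So does whether a chloro added to the 4-hydroxyphenyl ring would lower the number further.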